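The compounds below may be only part of what the source reports. "The series", "measured", "known", "first", "only" and "open" are said of these compounds alone.

Measured so far in a functional assay on the whole organism (strain AKR) for inhibition, with Mus musculus as the target, read by paw edema, with a stated time of 3.5 h, at a dose of 0.01 mmol/kg by the intraperitoneal route; a higher number here means more inhibition at the dose given (going by the name of the read-out), a lower number less inhibition:
compound 2, `O=C1N/C(=N\c2nccs2)S/C1=C\c1ccc(F)cc1`: 65.6%
compound 1, `O=C1N/C(=N\c2nccs2)S/C1=C\c1cccc(O)c1`: 33.7%

Of the two compounds measured, compound 2 stands highest. Its nearest neighbour, compound 1, lies a good way below it, and the gap between the two is beyond the usual scatter of this kind of measurement. Among the compounds with values here, the two compounds differ in more than one place, and no step between them has been computed; their values are taken only as they stand.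

Compound 3, `CN(C)c1ccc(/C=C2\S/C(=N/c3nccs3)NC2=O)cc1`, has not yet been measured. It differs from compound 2 in one place: dimethylamino in place of fluoro on an aromatic carbon. The shared core is kept. Within the data shown here, no measured pair differs in exactly this way, and there is no computed step to lean on. Among the measured compounds shown here, the only guide is the value of compound 2 in this assay together with the single change of group.

On that basis the step from compound 2 to compound 3 is expected to be a drop beyond the scatter, a number 17.6 percentage points lower from compound 2 to compound 3 (beyond the scatter). Compound 3 is estimated to give 48% in this assay, within a range from 22% to 72%.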

Compound 3, a percentage reported as inhibition, in the whole organism at one dose (the size of the read-out at that dose, not a potency): 67.3%
Compound 3: the middle estimate sits 19.3 percentage points below what was measured; low and high end bracket the measured number.
By their numbers in this assay, from the lowest: compound 1; then compounds 2 and 3 (each within the scatter of the next).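

In this assay, within the data shown here, putting dimethylamino in place of fluoro on an aromatic carbon, para to a large group, gives the first change at a single place that can be read, and the step reads a number 1.7 percentage points higher from compound 2 to compound 3 (within the scatter) at the one dose and time tested. At this position, then, a group of 3 heavy atoms with 1 hydrogen-bond acceptor can stand in for a single fluorine, which has no hydrogen-bond acceptor counted, with no difference that this measurement can resolve. The earlier compounds shown here could not show this, as they differ in more than one place and gave no step to read, so the position's response to a change of group was unknown until this pair.

Still open, on these data alone, is whether the same holds for other groups at this position, such as a carboxylic acid, a primary amine or a longer alkyl chain, and whether compound 2 and compound 3 would stay level at other doses. Nothing measured on these compounds bears on why the exchange leaves the read-out within the scatter.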